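The source may hold more compounds than are shown below. What is called first, only, known or untested is meant among the compounds shown, and "the series" means these compounds.

Compound 1 `O=C1C=C(Nc2cccc(Cl)c2)C(=O)c2c1nc1n2[C@H]2OC[C@@H](O)[C@H]2OC1` gives 1770 nM in a functional assay on MGC-803 cells (Homo sapiens) for inhibition, read by sulforhodamine B assay; a higher number here means a weaker inhibitor, a lower number a stronger inhibitor.
Compound 2 `CCCc1ccc(NC2=CC(=O)c3nc4n(c3C2=O)[C@H]2OC[C@@H](O)[C@H]2OC4)cc1` gives 1560 nM in this assay.

In this assay compound 2 stands alongside compound 1, the two numbers lying within the usual scatter of each other. Compound 3 `COc1ccccc1NC1=CC(=O)c2nc3n(c2C1=O)[C@H]1OC[C@@H](O)[C@H]1OC3` differs from compound 2 in one place: 2-methoxyphenyl in place of 4-propylphenyl on an amine nitrogen. Among the measured compounds shown here, the only measured step, a 1.1-fold lower number from compound 1 to compound 2 (0.05 log units; within the scatter), likewise exchanges one aryl group for another on the same amine nitrogen and stays within the scatter. On that basis the step to compound 3 is expected to stay within the scatter too, a 1.2-fold higher number from compound 2 to compound 3 (0.06 log units; within the scatter). Compound 3 is therefore estimated at 1800 nM, with a range from 700 nM to 4500 nM.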

Compound 3, half-maximal inhibitory concentration: 1630 nM
Estimate against measurement, compound 3: 1.1-fold (0.04 log units) above; the measured number falls inside the stated range.
By their numbers in this assay, from the lowest: compounds 2, 3 and 1 (each within the scatter of the next).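

Compound 3 adds a new kind of group at this amine nitrogen: 2-methoxyphenyl brings an oxygen and a hydrogen-bond acceptor, which 4-propylphenyl lacks, yet this assay shows only a 1.0-fold higher number from compound 2 to compound 3 (0.02 log units; within the scatter). The change from 3-chlorophenyl reads the same, with a 1.1-fold lower number from compound 1 to compound 3 (0.04 log units; within the scatter), so these three aryl groups cannot be told apart here. No independent measurement bears on this result.

On these data alone, it remains open whether a group other than a substituted phenyl at this nitrogen, such as a plain alkyl chain, or a phenyl ring bearing a carboxylic acid or an amine, would separate from these three.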